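The source may report more compounds than this note shows. Statements on the series, on what has been measured and on what is new or still open speak of the compounds shown alone.

Measured so far:
- compound 1, `Cc1ccc(-c2cccc(OC(=O)NC3CCCCC3)c2)cc1`, in an assay on cell membranes for binding affinity to Fatty-acid amide hydrolase 1 (Rattus norvegicus); a lower number here means a stronger inhibitor, a higher number a weaker inhibitor: 155 nM
- compound 2, `O=C(NC1CCCCC1)Oc1cccc(-c2cccc(-c3ccccc3)c2)c1`, in this assay: 565 nM

Both share the same core, a carbamate carrying a cyclohexyl group on its nitrogen and joined through its oxygen to a ring that in turn carries a second aromatic ring. They differ only in what sits on that second ring: a methyl group in compound 1, a phenyl group in compound 2. Of the two numbers, compound 2 has the higher one, and the gap down to compound 1 is beyond the usual scatter, so compound 2 is the weaker inhibitor of the pair.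

Compound 3, `CC(=O)c1cccc(-c2cccc(OC(=O)NC3CCCCC3)c2)c1`, keeps the core of compound 2 and changes a single place: acetyl in place of phenyl on an aromatic carbon. Among the compounds with values here, no pair differing in exactly this way has been measured, so the step has to be judged from the two values alone. Replacing the phenyl in compound 2 brought the number down in compound 1, which argues for a smaller group again giving a lower number here. Compound 3 is therefore expected to land at 150 nM, within roughly 50 nM to 500 nM, an expected step of a 3.8-fold lower number from compound 2 to compound 3 (0.58 log units; beyond the scatter).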

Compound 3, half-maximal inhibitory concentration: 9.1 nM
For compound 3 the middle estimate is 16-fold (1.22 log units) above the measured one; measured number outside the range, below it.
By their numbers in this assay, from the lowest: compound 3; then compound 1; then compound 2.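

Swapping phenyl for acetyl on this aromatic carbon gives a 62-fold lower number from compound 2 to compound 3 (1.79 log units; beyond the scatter) in this assay, so what sits at this position can move the number by a large margin, far more than compound 1 and compound 2 alone could show. The change is more than a loss of size: a carbon-only aromatic ring leaves, while the acetyl that enters has fewer heavy atoms, no ring, a carbonyl double bond and a hydrogen-bond acceptor, which the phenyl lacks. This single step cannot separate these differences, and no measurement here explains the result.

The compounds shown leave open whether the carbonyl oxygen of the acetyl matters or whether removing the phenyl ring is enough, a question that an ethyl group on the same carbon, a chain of carbon only, could help answer. They also leave open how other carbonyl-bearing groups, such as a carboxamide or a methyl ester, would compare with acetyl at this position.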